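A few compounds are considered here, and "the series" means these few. Any claim that something is new, unique, unknown or untested is made for them only; others in the source may bear on it.

In a physicochemical assay for solubility (on this read-out lower numbers stand for lower solubility and higher numbers for higher solubility), the series reads as follows:
compound 1 `CNC(=O)c1cc(C(=O)NC2CC2)cc2c1OC[C@H]2c1cccc2[nH]ccc12` gives >= 142 ug/mL (a limit)
compound 2 `CNC(=O)c1cc(C(=O)N[C@H]2[C@@H]3COC[C@@H]32)cc2c1OC[C@H]2c1cccc2[nH]ccc12` gives >= 171 ug/mL (a limit)
compound 3 `CNC(=O)c1cc(C(=O)N[C@H]2[C@@H]3COC[C@@H]32)cc2c1OC[C@H]2c1ccccc1` gives >= 165 ug/mL (a limit)

Compound 1 stands at the limit of >= 142 ug/mL in this assay, at which 1 of the 3 values shown sits, and so has no readable number. The other two values are limits as well.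

Compound 4 `CNC(=O)c1cc(C(=O)NC2CC2)cc2c1OC[C@H]2c1cccc(F)c1` carries 3-fluorophenyl in place of 1H-indol-4-yl on a saturated ring carbon.

The closest measured change is a step that the two limits leave unreadable from compound 2 to compound 3 with phenyl in place of 1H-indol-4-yl on the same carbon. The other one, a step that the two limits leave unreadable from compound 1 to compound 2 on an amide-type nitrogen, lies elsewhere in the structure. Neither shows a size or a direction, so no step beyond the scatter is expected in this assay for this change. The expected outcome is an at least 1.0-fold lower number from compound 1 to compound 4 (0.00 log units; that floor lies within the scatter) with no direction that the data can support. Compound 4 is estimated at 140 ug/mL with an expected range from 70 ug/mL to 200 ug/mL.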

Compound 4, solubility: >= 175 ug/mL
Compound 4: only a limit was reported (the forecaster's own chance of this, stated with the estimate: 55%); at least 1.2-fold (0.09 log units) between middle value and limit.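

In this assay compound 4 gives >= 175 ug/mL, a limit. Among these compounds, compound 1 gives >= 142 ug/mL, also a limit, so no step from compound 1 to compound 4 can be read. The compounds shown leave open whether 3-fluorophenyl in place of 1H-indol-4-yl moves the read-out of this assay in either direction.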